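Fluoro on the benzyl ring of a urea analogue

The source may report more compounds than this note shows. Statements on the series, on what has been measured and on what is new or still open speak of the compounds shown alone.

Measured so far:
Compound 1, `Cc1ccc(NC(=S)NC(=O)c2ccc(OCc3ccccc3F)cc2)cc1-c1nc2ccccc2[nH]1`: 1870 nM
Compound 2, `Cc1ccc(NC(=S)NC(=O)c2ccc(OCc3ccc(F)cc3)cc2)cc1-c1nc2ccccc2[nH]1`: 1910 nM
Compound 3, `Cc1ccc(NC(=O)NC(=O)c2ccc(OCc3ccccc3)cc2)cc1-c1nc2ccccc2[nH]1`: 16400 nM

All three compounds were tested in a functional assay on HT-29 cells (Homo sapiens) for inhibition, read by MTT assay, with a stated time of 48 h; a lower number here means a stronger inhibitor, a higher number a weaker inhibitor. Compound 3 gives the highest number of the three: the gap to compound 2 and to compound 1 lies beyond the scatter in each case, so compound 3 is the weakest inhibitor of the three.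

Compound 4, `Cc1ccc(NC(=O)NC(=O)c2ccc(OCc3ccccc3F)cc2)cc1-c1nc2ccccc2[nH]1`, has not yet been measured. It differs from compound 3 in one place: fluoro in place of hydrogen on an aromatic carbon, placed ortho to a large group on the benzyl ring.

For the measured compounds named here, no measured pair shows this exact change. Going by the values given here, the only measured step, a 1.0-fold higher number from compound 1 to compound 2 (0.01 log units; within the scatter), moves the fluoro from one position to another and leaves the number unchanged within the scatter; it tells nothing about adding the fluoro to a ring without it. Compounds 1 and 2 also differ from compound 3 in a second place, so their values cannot be read as a fluoro effect.

Compound 4 is therefore expected to stay close to compound 3, with a step of a 1.2-fold lower number from compound 3 to compound 4 (0.07 log units; within the scatter) no larger than the scatter, giving an estimated 14000 nM with a range from 6000 nM to 35000 nM.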

Compound 4, half-maximal inhibitory concentration: 760 nM
Compound 4: the middle estimate sits 18-fold (1.27 log units) above what was measured; measured number below the stated range.
By their numbers in this assay, from the lowest: compound 4; then compounds 1 and 2 (each within the scatter of the next); then compound 3.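

Adding a single fluoro to the benzyl ring, ortho to a large group, has a large effect: in this assay the step is a 22-fold lower number from compound 3 to compound 4 (1.33 log units; beyond the scatter). For the compounds shown here, the earlier pair only moved a fluoro from one ring position to another, so this is the first direct view of adding one to a ring without it, and it shows that replacing one hydrogen at this position can change the number well beyond the scatter. Nothing available explains why so small a change has so large an effect.

As far as these compounds go, it remains open whether fluoro is special here, since a chloro or a methoxy group on the same carbon might give a similar or very different number. Also open, from the compounds shown here alone, is whether 4-fluorophenyl in place of 2-fluorophenyl would leave the number of compound 4 unchanged, as did the same swap that gave a 1.0-fold higher number from compound 1 to compound 2 (0.01 log units; within the scatter).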